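This account rests on a few compounds, and the source may have more. Where it says the series, first, only, none or still open, it means among the compounds named here.

- compound 1 `CCOC(=O)/C=C(/C(=O)OC)[C@H]1c2c(cc(O)c(O)c2O)C(=O)O[C@@H]1C(=O)OCC`: 6000 nM
- compound 2 `CCOC(=O)/C=C(/C(=O)O)[C@H]1c2c(cc(O)c(O)c2O)C(=O)O[C@@H]1C(=O)OCC`: 8100 nM

In a functional assay, with a stated time of 30 min (a higher number here means that more compound is needed for the effect, a lower number that less compound is needed), compound 2 gives 8100 nM. That number lies within the scatter of the only other measured one, from compound 1 at 6000 nM.

Compound 3 `CCOC(=O)/C=C(/C(=O)OCC)[C@H]1c2c(cc(O)c(O)c2O)C(=O)O[C@@H]1C(=O)OCC` differs from compound 2 in one place: ethyl in place of hydrogen on an oxygen next to a carbonyl group. This is ethyl in place of hydrogen on an oxygen next to a carbonyl group, or carboxy to ethoxycarbonyl.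

For the measured compounds named here, one measured step bears on this change: a 1.4-fold higher number from compound 1 to compound 2 (0.13 log units; within the scatter), hydrogen in place of methyl on an oxygen next to a carbonyl group. Going by the values given here, that step stays within the scatter, and no measured compound yet carries ethyl there. In this assay, then, no shift beyond the scatter is expected. The expected step is a 1.4-fold lower number from compound 2 to compound 3 (0.13 log units; within the scatter), which is within the scatter. Compound 3 is estimated at 6000 nM, with an expected range from 2500 nM to 14000 nM.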

Compound 3, half-maximal effective concentration: 2200 nM
Beside the measured number, compound 3's estimate is 2.7-fold (0.44 log units) above it; the whole stated range lies above it.
By their numbers in this assay, from the lowest: compound 3; then compounds 1 and 2 (each within the scatter of the next).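

Carboxy to ethoxycarbonyl gives a 3.7-fold lower number from compound 2 to compound 3 (0.57 log units; beyond the scatter) in this assay and so shows that this position does answer to what sits on the oxygen, which the step between compound 1 and compound 2, within the scatter, did not show. Methyl in place of hydrogen on a saturated chain carbon bound to an oxygen next to a carbonyl group gives a 2.7-fold lower number from compound 1 to compound 3 (0.44 log units; beyond the scatter) in this assay as well, so ethyl parts from both methyl and hydrogen here, while those two stay within the scatter of each other. Nothing available explains this difference. Going by these compounds, whether a longer chain such as propyl or butyl would go further in the same direction, or a branched chain such as isopropyl would keep the lower number, stays open. So does the effect of an amide at this place.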